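The source may hold more compounds than are shown below. What is called first, only, known or untested is meant among the compounds shown, and "the series" means these compounds.

Measured compounds:
Compound 1, `CN(C)C(=O)n1cc(C(=O)c2ccn3c2CSC3c2cccnc2)c2ccc(OCc3ccccc3)cc21`, in a functional assay (Oryctolagus cuniculus) for antagonist activity at platelet-activating factor receptor (Cavia porcellus) (on this read-out lower numbers stand for stronger inhibition and higher numbers for weaker inhibition), compound 1 gives 17 nM.
Compound 2, `NC(=O)n1cc(C(=O)c2ccn3c2CSC3c2cccnc2)c2ccc(-c3ccc(F)cc3)cc21`, in this assay compound 2 gives 6 nM.

Within the data shown here, compound 2 holds the lowest number of the two, and its nearest neighbour is compound 1, whose number stands beyond the scatter above it; with only two compounds, the values show no more than that difference. Compound 3, `O=C(O)CCn1cc(C(=O)c2ccn3c2CSC3c2cccnc2)c2ccc(-c3ccc(F)cc3)cc21`, has not yet been measured in this assay. It differs from compound 2 in one place: 2-carboxyethyl in place of carbamoyl on an aromatic nitrogen. Among the measured compounds shown here, no measured pair tells what such an exchange does here, so the expected size of the step rests on the measured range alone. A modest rise in the number, just beyond the scatter, is expected for the step of a 2.5-fold higher number from compound 2 to compound 3 (0.40 log units; beyond the scatter). Compound 3 is accordingly estimated at 15 nM, with a range from 4 nM to 60 nM.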

Compound 3, inhibition constant: 160 nM
The estimate for compound 3 lay 11-fold (1.03 log units) below the measured number; the whole stated range lies below it.
By their numbers in this assay, from the lowest: compound 2; then compound 1; then compound 3.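

Exchanging carbamoyl for 2-carboxyethyl on the aromatic nitrogen gives a 27-fold higher number from compound 2 to compound 3 (1.43 log units; beyond the scatter) in this assay, so inhibition at this position depends strongly on which group is attached. Among these compounds, this is the first single-place exchange measured here, and the large step arises even though the two groups have the same count of hydrogen-bond donors and acceptors, with 5 heavy atoms entering and 3 leaving. Nothing available bears on the reason for the size of this step.

The compounds shown leave open whether the rise in the number goes with the carboxylic acid or with the longer chain; a 2-carbamoylethyl group or a carboxymethyl group on the same nitrogen would separate the two. Also open, going by these compounds, is how a simple methyl group or an amine-bearing chain would behave there.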